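This account rests on a few compounds, and the source may have more. Where it says the series, first, only, none or still open, it means among the compounds named here.

Compound 3 `Nc1ccccc1NC(=O)/C=C/c1ccc(Cn2cnc3c(Nc4ccccc4)nc(Cl)nc32)cc1` sits in the middle of the three measured compounds: in a functional assay on NCI-H460 cells (Homo sapiens) for antiproliferative activity, read by CCK-8 assay, with a stated time of 72 h, tested at 8 uM (a higher number here means a stronger effect of the compound at the concentration tested, a lower number a weaker effect), compound 3 gives 28.7%. Compound 2 `Cc1ccc(Nc2nc(Cl)nc3c2ncn3Cc2ccc(/C=C/C(=O)Nc3ccccc3N)cc2)cc1` gives 51.3% in this assay, and compound 1 `CC1CCN(c2nc(Cl)nc3c2ncn3Cc2ccc(/C=C/C(=O)Nc3ccccc3N)cc2)CC1` gives 10.8% in this assay, so compound 3 lies a number 17.9 percentage points higher from compound 1 to compound 3 (beyond the scatter) and a number 22.6 percentage points lower from compound 2 to compound 3 (beyond the scatter).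

Compound 4 `Nc1ccccc1NC(=O)/C=C/c1ccc(Cn2cnc3c(NCc4ccccc4)nc(Cl)nc32)cc1` differs from compound 3 only at the group on the nitrogen: benzyl in place of phenyl on a nitrogen on an aromatic ring. Going by the values given here, no measured step exchanges phenyl for benzyl. Among the compounds with values here, the steps that bear on this position are those that replace the group on the same carbon of the core: a number 40.5 percentage points higher from compound 1 to compound 2 (beyond the scatter) and a number 17.9 percentage points higher from compound 1 to compound 3 (beyond the scatter), both beyond the scatter, while the smaller change a number 22.6 percentage points lower from compound 2 to compound 3 (beyond the scatter) was also beyond it. Changes here therefore move the read-out in this assay noticeably, but the direction for benzylamino cannot be read from these compounds.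

For compound 4 a step of a number 4.7 percentage points lower from compound 3 to compound 4 (within the scatter) is expected, a modest drop within wide uncertainty. Compound 4 is estimated at 24% in this assay, with a range from 8% to 50%.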

Compound 4, a percentage reported as inhibition, at one concentration (the size of the read-out at that concentration, not a potency): 49.1%
Beside the measured number, compound 4's estimate is 25.1 percentage points below it; the range from low to high includes it.
By their numbers in this assay, from the lowest: compound 1; then compound 3; then compounds 4 and 2 (each within the scatter of the next).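

Benzyl in place of phenyl on the nitrogen gives a number 20.4 percentage points higher from compound 3 to compound 4 (beyond the scatter) in this assay, so this position responds to a change in the link to the ring as well as to a substituent on it. Compared with the 4-methylphenyl group, benzyl gives a number 2.2 percentage points lower from compound 2 to compound 4 (within the scatter), which means that in this small set, two different changes to the anilino group of compound 3 lead to values that cannot be told apart. Benzylamino in place of 4-methylpiperidin-1-yl gives a number 38.3 percentage points higher from compound 1 to compound 4 (beyond the scatter), so compound 1 remains beyond the scatter from compounds 2, 3 and 4 alike. Nothing shown gives a reason for these steps. The compounds leave open whether a longer chain such as 2-phenylethyl on the nitrogen, or a methyl on the ring of the benzyl group, would change the read-out further.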